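Removing one ring methyl on the way to compound 3

The source may hold more compounds than are shown below. What is called first, only, known or untested is meant among the compounds shown, and "the series" means these compounds.

Measured in a functional assay on ACHN cells (Homo sapiens) for antiproliferative activity, read by sulforhodamine B assay; on this read-out lower numbers stand for stronger inhibition of growth and higher numbers for weaker inhibition of growth:
- compound 1 `CC1CC(=O)c2s/c(=N/c3ccccc3)oc2C1` gives 2980 nM
- compound 2 `CC1(C)CC(=O)c2s/c(=N/c3ccc(Cl)cc3)oc2C1` gives 9810 nM

Compound 2 stands at the higher of the two numbers in this assay, and its gap to compound 1 is beyond the scatter. Compound 3 `CC1CC(=O)c2s/c(=N/c3ccc(Cl)cc3)oc2C1` differs from compound 2 by hydrogen in place of methyl on a saturated ring carbon, with hydrogen in place of methyl on a saturated ring carbon. Among the compounds with values here, no step of this kind has been measured here, so only a modest expectation can be drawn. Compound 3 is expected to move by a 1.8-fold lower number from compound 2 to compound 3 (0.25 log units; within the scatter) toward compound 1, landing near 5500 nM, within 1800 nM to 16000 nM.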

Compound 3, concentration for 50% growth inhibition: 12400 nM
For compound 3 the middle estimate is 2.3-fold (0.35 log units) below the measured one; the measured number falls inside the stated range.
By their numbers in this assay, from the lowest: compound 1; then compounds 2 and 3 (each within the scatter of the next).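

In this assay, a step of a 1.3-fold higher number from compound 2 to compound 3 (0.10 log units; within the scatter) comes with hydrogen in place of methyl on a saturated ring carbon, so this change has no readable effect on growth inhibition here. A step of a 4.2-fold higher number from compound 1 to compound 3 (0.62 log units; beyond the scatter) comes with chloro in place of hydrogen on an aromatic carbon, and of the two single changes only this one lies beyond the scatter. No measurement at hand gives a cause for either step.

On these data alone, whether an ethyl or a hydroxyl group on the saturated ring carbon would change the read-out remains open. So does the effect of a methoxy or fluoro group on the aromatic carbon in place of chloro.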